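This account rests on a few compounds, and the source may have more. Where it says the series, first, only, none or still open, it means among the compounds named here.

Working notes on the series. In a functional assay on PANC-1 cells (Homo sapiens) for inhibition, read by XTT assay, with a stated time of 72 h (on this read-out higher numbers stand for weaker inhibition and lower numbers for stronger inhibition), compound 1 `CCCCCCCC/C=C\CCCCCCCCOC[C@@H]1CCCN1` gives 4700 nM. Compound 2 `CCCCCCCC/C=C\CCCCCCCCOC[C@@H]1CCCN1C(=O)[C@@H]1CCCN1C(=O)OC(C)(C)C` reads > 100000 nM, which is a limit of the assay and not a number. Compound 3 `CCCCCCCC/C=C\CCCCCCCCOC[C@@H]1CCCN1C(=O)[C@@H]1CCCN1` differs from compound 2 by one change, hydrogen in place of tert-butoxycarbonyl on an amine nitrogen in a ring. Compound 1 reaches 4700 nM without a tert-butoxycarbonyl group, and compound 3 lacks it too. A large step toward stronger inhibition in this assay is therefore expected, an at least 11-fold lower number from compound 2 to compound 3 (1.04 log units; beyond the scatter). Compound 3 is estimated at 9000 nM, with an expected range of 3000 nM to 30000 nM.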

Compound 3, half-maximal inhibitory concentration: 5000 nM
Compound 3: middle estimate off by 1.8-fold (0.26 log units), on the high side; the range from low to high includes it.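

In this assay, hydrogen in place of tert-butoxycarbonyl on an amine nitrogen in a ring gives an at least 20-fold lower number from compound 2 to compound 3 (1.30 log units; beyond the scatter), the first sign that this position is sensitive to what it carries. Compound 2 stands at a limit, not a number, and the true size of this step stays unread: the limit of > 100000 nM in this assay, at which 1 of the 3 values shown sits. With that nitrogen bearing hydrogen, (pyrrolidin-2-yl)carbonyl in place of hydrogen on the core of compound 1 gives a 1.1-fold higher number from compound 1 to compound 3 (0.03 log units; within the scatter). Open, going by these compounds, is whether the loss belongs to tert-butoxycarbonyl alone or extends to smaller groups on this nitrogen, such as acetyl or methyl.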